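This account rests on a few compounds, and the source may have more. Where it says the series, first, only, none or still open, it means among the compounds named here.

Going by the values given here, compound 2, `CC(C)(C)OC(=O)CNC(=O)c1[nH]cnc1C(=O)Nc1ccc(Cl)c(Cl)c1`, is one of two compounds measured in a functional assay on HL-60 cells (Homo sapiens), with a stated time of 2 days; on this read-out lower numbers stand for stronger inhibition and higher numbers for weaker inhibition. In this assay compound 2 gives 49800 nM, the higher of the two numbers. Its nearest neighbour is compound 1, `C[C@@H](NC(=O)c1[nH]cnc1C(=O)Nc1ccc(Cl)c(Cl)c1)c1ccccc1`, which in this assay gives 8800 nM. Among the compounds with values here, the single measured step, a 5.7-fold higher number from compound 1 to compound 2 (0.75 log units; beyond the scatter), replaces the 1-phenylethyl group with (tert-butoxycarbonyl)methyl on the amide-type nitrogen, and it lies beyond the scatter.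

Compound 3, `C[C@H](NC(=O)c1[nH]cnc1C(=O)Nc1ccc(Cl)c(Cl)c1)C(=O)OC(C)(C)C`, is not yet measured. It differs from compound 2 by methyl in place of hydrogen on a saturated chain carbon bound to an amide-type nitrogen and a carbonyl carbon. Within the data shown here, no measured step isolates this change: the step from compound 1 to compound 2 swaps the whole group on the amide-type nitrogen, so it carries no separate reading on adding a methyl to the saturated chain carbon bound to an amide-type nitrogen and a carbonyl carbon. Compound 1 does carry a methyl on such a carbon, but its other parts differ too. He therefore expects at most a modest step, a 1.4-fold lower number from compound 2 to compound 3 (0.15 log units; within the scatter), and estimates compound 3 in this assay at 35000 nM, within a range from 12000 nM to 100000 nM.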

Compound 3, half-maximal inhibitory concentration: 4900 nM
Compound 3: middle estimate off by 7.1-fold (0.85 log units), on the high side; measured number below the stated range.
By their numbers in this assay, from the lowest: compounds 3 and 1 (each within the scatter of the next); then compound 2.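

In this assay the methyl on the saturated chain carbon bound to an amide-type nitrogen and a carbonyl carbon proves to be a large change for a single carbon, with a 10-fold lower number from compound 2 to compound 3 (1.01 log units; beyond the scatter) as the step. The earlier step swapped the whole group on the amide-type nitrogen, so it could not show this; with the methyl in place, the gap seen in a 5.7-fold higher number from compound 1 to compound 2 (0.75 log units; beyond the scatter) no longer stands, and a 1.8-fold lower number from compound 1 to compound 3 (0.25 log units; within the scatter) leaves 1-(tert-butoxycarbonyl)ethyl and 1-phenylethyl on that nitrogen within the scatter of each other. Nothing given here explains why this methyl has so large an effect on the read-out.

The compounds shown leave open whether the methyl would count for as much with a carboxylic acid in place of the tert-butyl ester, since the step rests on this one pair. They also do not tell whether a longer chain such as ethyl on the same carbon would go further, or whether the mirror-image arrangement at that carbon would give the same number.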